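The source may hold more compounds than are shown below. What is called first, only, known or untested is meant among the compounds shown, and "the series" means these compounds.

Working notes on the series. Compound 1 `O=C(COc1ccc2cc(C(O)(C(F)(F)F)C(F)(F)F)c(O)cc2c1)Nc1ccccc1` carries an amide-type nitrogen bearing a hydrogen and a phenyl. In an assay on isolated protein for inhibition of tyrosine-protein phosphatase non-receptor type 13 (Homo sapiens), read by spectrophotometry (a higher number here means a weaker inhibitor, a lower number a stronger inhibitor), compound 1 gives > 20000 nM, which is a limit of the assay and not a number. Compound 2 `COc1ccc(CNC(=O)COc2ccc3cc(C(O)(C(F)(F)F)C(F)(F)F)c(O)cc3c2)cc1OC` is the same compound with 3,4-dimethoxybenzyl in place of phenyl on that nitrogen. In this assay compound 2 gives > 20000 nM, again a limit and not a number. The step that the two limits leave unreadable from compound 1 to compound 2 therefore cannot be read in size or direction; both values sit at the limit of > 20000 nM in this assay, at which 2 of the 2 values shown sit. Compound 1 stands only at a limit, with no number to rank it against.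

Compound 3 `O=C(COc1ccc2cc(C(O)(C(F)(F)F)C(F)(F)F)c(O)cc2c1)N(c1ccccc1)c1ccccc1` differs from compound 1 by phenyl in place of hydrogen on an amide-type nitrogen. Among the compounds with values here, the only measured step that touches this nitrogen is the one from compound 1 to compound 2, and it is unreadable, so no measured step points to a size or direction for the change in this assay. The expected step that the limit leaves unreadable from compound 1 to compound 3 is accordingly set at no change beyond the scatter, with the assay most likely returning a limit again. Compound 3 is expected at 30000 nM, within a range from 10000 nM to 100000 nM.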

Compound 3, half-maximal inhibitory concentration: 12400 nM
For compound 3 the middle estimate is 2.4-fold (0.38 log units) above the measured one; the measured number falls inside the stated range.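

Within the data shown here, putting phenyl in place of the amide hydrogen gives the first readable number: in this assay compound 3 gives 12400 nM, so a nitrogen bearing two phenyl groups is compatible with measurable inhibition in this assay. As far as these compounds go, the data give an at least 1.6-fold lower number from compound 1 to compound 3 (0.20 log units; that floor lies within the scatter), and this is only a floor, so the true size of the step is unknown and the result does not establish a change beyond the scatter. The other two compounds, compound 1 and compound 2, remain at a limit, and the step between them still cannot be read: the limit of > 20000 nM in this assay, at which 2 of the 3 values shown sit.

Still open, from the compounds shown here alone, is whether the number in compound 3 depends on the added phenyl itself or on the amide nitrogen no longer carrying a hydrogen, which a methyl or a longer alkyl chain in place of that hydrogen would help to separate. Among these compounds, also open is how a carboxylic acid or an amine on the added phenyl would move the value, and no step yet has a number at both ends.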